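The source may hold more compounds than are shown below. What is called first, only, known or untested is meant among the compounds shown, and "the series" means these compounds.

Among the two compounds measured in an assay on isolated protein for inhibition of Nitric oxide synthase, inducible (Homo sapiens), read by scintillation counting, with a stated time of 30 min, tested at 50 uM (on this read-out higher numbers stand for more inhibition at the one concentration tested (going by the name of the read-out) and lower numbers for less inhibition), compound 2 `CCCC(=O)N1N=C(c2ccccc2N)SC1(C)C` stands highest, giving 35.2%, while compound 1 `CC(=O)N1N=C(c2ccccc2N)SC1(C)C` gives 22.9%. Among the measured compounds shown here, the one measured step, a number 12.3 percentage points higher from compound 1 to compound 2 (beyond the scatter), already changes the group on a carbonyl carbon whose other neighbour is an amide-type nitrogen in a ring. Compound 3 `CC1(C)SC(c2ccccc2N)=NN1C(=O)C1CCCC1` changes that same group again: cyclopentyl in place of propyl on a carbonyl carbon. Since the earlier step at this place gave a modest gain, a further modest gain is expected, though one that could sit within the scatter; the expected step is a number 6.8 percentage points higher from compound 2 to compound 3 (within the scatter). Compound 3 is therefore estimated at 42%, within a range from 25% to 60%.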

Compound 3, a percentage reported as inhibition, at one concentration (the size of the read-out at that concentration, not a potency): 42.2%
For compound 3 the middle estimate is 0.2 percentage points below the measured one; the range from low to high includes it.
By their numbers in this assay, from the lowest: compound 1; then compounds 2 and 3 (each within the scatter of the next).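

Swapping the open propyl chain for a ring on the carbonyl carbon gives a number 7 percentage points higher from compound 2 to compound 3 (within the scatter) and so shows that a ring can stand here without a clear change from compound 2. The gain over the small methyl group of compound 1 holds up for the ring too, with a number 19.3 percentage points higher from compound 1 to compound 3 (beyond the scatter) as the step. Nothing measured here explains these numbers. Still open, going by these compounds, is how a phenyl ring, a cyclohexyl ring or an amine-bearing chain on this carbonyl carbon would compare with compound 3.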